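A few compounds are considered here, and "the series" means these few. Any claim that something is new, unique, unknown or untested is made for them only; others in the source may bear on it.

For the measured compounds named here, compound 2 `CCCNC(=O)c1cc(Oc2ccc(NC(=O)c3cc4cccnc4n(-c4ccccc4)c3=O)cc2)ccn1` is the only compound here with a measured number: in a functional assay on U-87MG ATCC cells for antiproliferative activity against U-87 MG (Homo sapiens), read by MTT assay, with a stated time of 72 h (a higher number here means a weaker inhibitor, a lower number a stronger inhibitor), compound 2 gives 1510 nM. Compound 1 `CCNC(=O)c1cc(Oc2ccc(NC(=O)c3cc4cccnc4n(-c4ccc(Br)cc4)c3=O)cc2)ccn1` shares the same core, but in this assay compound 1 gives "not determined" (no result reported). Compound 3 `CCCNC(=O)c1cc(Oc2ccc(NC(=O)c3cc4cccnc4n(-c4ccc(Br)cc4)c3=O)cc2)ccn1` differs from compound 2 in one place: bromo in place of hydrogen on an aromatic carbon, a bromo in place of hydrogen on an aromatic carbon. Going by the values given here, no step between two measured compounds shows what this change does, so the step expected in this assay, a 1.3-fold lower number from compound 2 to compound 3 (0.10 log units; within the scatter), is small and lies within the usual scatter. Compound 3 is therefore estimated at 1200 nM, with a range from 400 nM to 3600 nM.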

Compound 3, half-maximal inhibitory concentration: 5190 nM
The estimate for compound 3 lay 4.3-fold (0.64 log units) below the measured number, outside the stated range (above it).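

In this assay, going from phenyl to 4-bromophenyl brings a 3.4-fold higher number from compound 2 to compound 3 (0.54 log units; beyond the scatter). A bromo at this place on the ring therefore makes the inhibitor weaker, which shows that this position is sensitive to at least this one change. Nothing available here explains the loss of activity. The compounds shown leave open whether a fluoro, a methoxy or an amine at the same place would also weaken the compound. They also leave open whether a hydrogen-to-bromo change would act the same way with a different side chain.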